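The source may hold more compounds than are shown below. What is called first, only, known or untested is meant among the compounds shown, and "the series" means these compounds.

Of the compounds shown here, two have so far been tested in a functional assay on HFL1 cells (Homo sapiens) for inhibition, read by sulforhodamine B assay, with a stated time of 48 h; on this read-out lower numbers stand for stronger inhibition and higher numbers for weaker inhibition. Compound 1, `COc1ccc(-c2nnc(NC3=NC(=O)/C(=C/c4ccc(N(C)C)cc4)S3)o2)cc1`, gives 150 nM in this assay. Compound 2, `O=C1CS/C(=N/N=C/c2cccnc2)N1`, a considerably smaller molecule, gives 810 nM in this assay. Of the two numbers, compound 2 has the higher one, so it is the weaker inhibitor of the pair, and its gap to compound 1 lies beyond the usual scatter of repeated measurements.

Compound 3, `CC1S/C(=N/N=C/c2cccnc2)NC1=O`, has not yet been measured. It differs from compound 2 in a single place: methyl in place of hydrogen on a saturated ring carbon. Among the compounds with values here, nothing measured so far shows what such a change does on this framework, since no pair of measured compounds differs only there. Within the data shown here, a methyl in place of a hydrogen is a small change, and with no comparable pair to lean on, the expected step is one that stays close to the scatter, with no clear direction: the estimated step is a 1.0-fold lower number from compound 2 to compound 3 (0.01 log units; within the scatter) in this assay. On that basis compound 3 is expected to give about 800 nM in this assay, with a likely range from 300 nM to 2500 nM.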

Compound 3, half-maximal inhibitory concentration in the HFL1 assay: 830 nM
For compound 3 the middle estimate is 1.0-fold (0.02 log units) below the measured one; the measured number falls inside the stated range.
By their numbers in the HFL1 assay, from the lowest: compound 1; then compounds 2 and 3 (each within the scatter of the next).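

Within the data shown here, in the HFL1 assay this is the first pair of measured compounds that differ in one place, and the step is a 1.0-fold higher number from compound 2 to compound 3 (0.01 log units; within the scatter), so on this framework a methyl in place of hydrogen on a saturated ring carbon, next to the ring sulfur, brings no change that can be told from the scatter. Among these compounds, this is one pair and one small group, so it shows only that this particular swap leaves the number where it was, and no measured evidence is available here to explain that result. In a physicochemical assay for inhibition, with a stated time of 3 min (on this read-out higher numbers stand for larger maximal responses and lower numbers for smaller maximal responses), compound 2 is recorded as "not determined" (no result reported) and compound 3 gives 35.8% as its result, so the step cannot be read on this second read-out.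

The compounds shown leave open whether the same ring carbon would behave the same way with a larger or different group on it, such as an ethyl or longer chain, a phenyl ring, an amine or a carboxylic acid. Compound 1 differs from compound 2 and compound 3 in more than one place, so it adds nothing about this position.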